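A few compounds are considered here, and "the series" means these few. Any claim that something is new, unique, unknown or untested is made for them only; others in the source may bear on it.

Measured so far:
compound 1 `O=C(O)c1ccc(-c2cccc(COc3ccc4c(c3)CN(C3CCCC3)C4=O)c2)c(Cl)c1` gives 3%
compound 2 `CC(C)Cn1sc2cc(OCc3cccc(-c4ccc(Cl)c(C(=O)O)c4)c3)ccc2c1=O` gives 86%

In an ADME assay on microsomes from liver (Rattus norvegicus) for metabolic stability, read by LC-MS, with a stated time of 1 h, at 37 degrees C, tested at 4 uM (on this read-out lower numbers stand for a less stable compound and higher numbers for a more stable compound), compound 1 gives 3%, the lowest of the two numbers shown, and compound 2 gives 86%, a gap far beyond the usual scatter. Among the measured compounds shown here, no pair differing in a single place has been measured, so the two values stand alone for comparison. Compound 3 `O=C(O)c1cc(F)cc(-c2cccc(COc3ccc4c(c3)CN(C3CCCC3)C4=O)c2)c1` differs from compound 1 by 3-carboxy-5-fluorophenyl in place of 4-carboxy-2-chlorophenyl on an aromatic carbon. With no matching change among the measured compounds, only a modest step is expected in this assay. The expected step of a number 7 percentage points higher from compound 1 to compound 3 (within the scatter) is upward and may not clear the scatter. Compound 3 is expected to give 10%, within 2% to 35%.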

Compound 3, percent of the compound remaining: 55%
Compound 3: the middle estimate sits 45 percentage points below what was measured, and the stated range ends below it.
By their numbers in this assay, from the lowest: compound 1; then compound 3; then compound 2.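

In this assay, on the core of compound 1, 3-carboxy-5-fluorophenyl in place of 4-carboxy-2-chlorophenyl on an aromatic carbon gives a number 52 percentage points higher from compound 1 to compound 3 (beyond the scatter) with the rest of the structure unchanged. Among the compounds shown here, this is the first single-place step, and it shows that this aryl group alone can move the read-out far. Nothing at hand bears on the reason for this step.

On these data alone, how the step divides between the change of halogen and the new place of the carboxylic acid stays open; a 3-carboxy-5-chlorophenyl group would separate the two. As far as these compounds go, whether a primary carboxamide could stand in for the carboxylic acid also stays open.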